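The compounds below may be only part of what the source reports. "The series", "measured", "known", "first", "only" and "open" are said of these compounds alone.

Measured compounds:
compound 1 `C=C1C(=O)C[C@H]2[C@@H]3CC[C@H](C(=O)O)[C@]12CC3(C)C` — in a functional assay on SF-268 cells (Homo sapiens) for cytotoxicity, read by MTT assay, with a stated time of 48 h (on this read-out higher numbers stand for weaker inhibition and lower numbers for stronger inhibition), compound 1 gives 14700 nM
compound 2 `COC1=C(c2c[nH]c3ccccc23)C(=O)C(OC)=C(c2c[nH]c3ccccc23)C1=O` — in this assay compound 2 gives 15800 nM

Compound 1 and compound 2 give numbers that lie within the scatter of each other, so neither stands apart on this read-out. Compound 3 `C=C1C(=O)C[C@H]2[C@@H]3CC[C@H](C(=O)OC)[C@]12CC3(C)C` differs from compound 1 by methyl in place of hydrogen on an oxygen next to a carbonyl group. Going by the values given here, no measured pair shows what this change does in this assay, so the expectation rests on compound 1 alone. Compound 3 is expected to stay close to compound 1. The step of a 1.5-fold lower number from compound 1 to compound 3 (0.17 log units; within the scatter) is expected to be small, in an uncertain direction, hardly beyond the scatter. The estimate for compound 3 in this assay is 10000 nM, with a range from 3000 nM to 35000 nM.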

Compound 3, half-maximal inhibitory concentration: 10200 nM
For compound 3 the middle estimate is 1.0-fold (0.01 log units) below the measured one, and the stated range covers the measured number.
By their numbers in this assay, from the lowest: compounds 3, 1 and 2 (each within the scatter of the next).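

Putting methyl in place of hydrogen on an oxygen next to a carbonyl group, which turns carboxy into methoxycarbonyl, gives a 1.4-fold lower number from compound 1 to compound 3 (0.16 log units; within the scatter) in this assay and stays within the scatter. Going by these compounds alone, this is the first measured change at this position, and it shows that the read-out holds with the hydrogen replaced by methyl. Nothing available explains why the step is this small.

On these data alone, what an ethyl group or a longer chain on that oxygen would do remains open. So does the effect of an amide or an amine in place of the methoxycarbonyl.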